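Sulfonyl group swap in a series read only as limits

The compounds below may be only part of what the source reports. "The series", "measured", "known", "first", "only" and "open" are said of these compounds alone.

Compound 1 `CC1CCN(C2CCN(S(=O)(=O)c3cccnc3F)CC2)CC1`, compound 2 `CC1CCN(C2CCN(S(=O)(=O)c3ccc(Cl)nc3)CC2)CC1` and compound 3 `CC1CCN(C2CCN(S(=O)(=O)c3cccc(Cl)c3)CC2)CC1` differ only in the group on the sulfonyl sulfur. In an ADME assay on HCT-116 cells (Homo sapiens) for cytotoxicity, read by CellTiter-Glo, with a stated time of 72 h (on this read-out higher numbers stand for weaker inhibition and lower numbers for stronger inhibition), compound 1 gives > 10000 nM, which is a limit. Compound 2 gives > 10000 nM, also a limit. Compound 3 gives > 5000 nM, again a limit, so it has no numerical value in this assay. The three results rest on the limit of > 10000 nM in this assay, at which 2 of the 3 values shown sit, and on (the limit of > 5000 nM in this assay, at which 1 of the 3 values shown sits).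

Compound 4 `CC1CCN(C2CCN(S(=O)(=O)c3cn(C)cn3)CC2)CC1` has not yet been measured. It carries 1-methyl-1H-imidazol-4-yl in place of 3-chlorophenyl on a sulfonyl sulfur.

Three measured steps at this same place bear on the change: a step that the two limits leave unreadable from compound 1 to compound 2, a step that the two limits leave unreadable from compound 1 to compound 3 and a step that the two limits leave unreadable from compound 2 to compound 3. None of them has a readable size, so they offer no measured size or direction to carry over. The expectation for compound 4 rests on the limit of compound 3 at > 5000 nM. The estimated step is a step that the limit leaves unreadable from compound 3 to compound 4, with no direction expected beyond the scatter. The result will most likely be reported as a limit again. For compound 4 the expected value in this assay is 10000 nM, with an estimated range from 5000 nM to 20000 nM.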

Compound 4, half-maximal inhibitory concentration: > 10000 nM
Compound 4 was reported as a limit (the forecaster's own chance of this, stated with the estimate: 90%); the middle value sits exactly at the limit.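

In this assay compound 4 gives > 10000 nM, which is a limit, so the steps to compound 4 from compound 1, compound 2 and compound 3 cannot be read. The compounds shown leave open whether any of these four groups on the sulfonyl sulfur gives a numerical value in this assay, and how the four would rank.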